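A few compounds are considered here, and "the series" means these few. Any claim that something is new, unique, unknown or untested is made for them only; others in the source may bear on it.

Measured so far: compound 1 `CCOC(=O)C1=C(Nc2ccccc2)S/C(=C\c2ccc[nH]2)C1=O`, 49.2%; compound 2 `CCOC(=O)C1=C(Nc2ccccc2Br)S/C(=C\c2ccc[nH]2)C1=O`, 62.7%.

In a functional assay on JAR cells (Homo sapiens) for inhibition, read by MTT assay, with a stated time of 72 h, tested at 10 uM (a lower number here means less inhibition, a higher number more inhibition at the concentration tested (going by the name of the read-out)), compound 1 gives 49.2%, the lowest of the two numbers shown. Compound 2 gives 62.7%, and the step of a number 13.5 percentage points higher from compound 1 to compound 2 (beyond the scatter) lies beyond the scatter. Compound 3 `CCOC(=O)C1=C(Nc2cccc(C(F)(F)F)c2)S/C(=C\c2ccc[nH]2)C1=O` differs from compound 1 by trifluoromethyl in place of hydrogen on an aromatic carbon. Among the measured compounds shown here, no measured step covers this exact change; the only step, bromo in place of hydrogen, concerns a different group at a different aromatic carbon and so bears on it only loosely. For compound 3 a modest rise is expected, about a number 6.8 percentage points higher from compound 1 to compound 3 (within the scatter). Compound 3 is therefore estimated at 56%, within a range from 40% to 72%.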

Compound 3, a percentage reported as inhibition, at one concentration (the size of the read-out at that concentration, not a potency): 52.9%
The estimate for compound 3 lay 3.1 percentage points above the measured number; low and high end bracket the measured number.
By their numbers in this assay, from the lowest: compounds 1, 3 and 2 (each within the scatter of the next, the first and the last beyond it).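

In this assay, trifluoromethyl on this aromatic carbon, meta to a large group, gives a number 3.7 percentage points higher from compound 1 to compound 3 (within the scatter). A group of 4 heavy atoms can therefore stand at this place on compound 1 with a result that cannot be told apart from that of the hydrogen it replaces. Nothing measured here bears on why this is so.

On these data alone, whether an amine or a carboxylic acid at this same carbon would give a similar number remains open. So does whether trifluoromethyl would give a similar number on another carbon of this ring.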